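A few compounds are considered here, and "the series" means these few. Any claim that something is new, unique, unknown or untested is made for them only; others in the source may bear on it.

Of the compounds shown here, three that share one core have been tested in a functional assay on RKO cells (Homo sapiens) for inhibition, read by MTT assay, with a stated time of 48 h; on this read-out higher numbers stand for weaker inhibition and lower numbers for stronger inhibition. Compound 1 `C[Se]c1ccc(N(C)c2nc(C3CC3)nc3ccccc23)cc1` gives 21 nM in this assay. Compound 3 `Cc1nc(N(C)c2ccc([Se]C#N)c(C)c2)c2ccccc2n1` gives 17 nM. Compound 2 `COc1ccc(N(C)c2nc(C)nc3ccccc23)cc1OCCCCCC[Se]C#N` gives 1540 nM, the highest of the three numbers; its inhibition is weaker than that of compound 1 and of compound 3 by margins beyond the usual scatter of repeated measurements.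

For the measured compounds named here, the one compound not yet measured is compound 4 `COc1ccc(N(C)c2nc(C)nc3ccccc23)cc1C[Se]C#N`. It differs from compound 2 in a single place: a group of 4 heavy atoms (2 carbon, 1 nitrogen, 1 selenium; no ring) in place of a group of 10 heavy atoms (7 carbon, 1 nitrogen, 1 oxygen, 1 selenium; no ring), on an aromatic carbon The selenium-bearing group is thus cut down from a long chain to a much smaller piece, an arrangement more like that of compound 3, which carries its selenocyanate on a short group as well.

Going by the values given here, no measured pair in this set shows exactly this change, so the size of the step rests on comparison. Compound 3 reaches 17 nM with a compact selenium group, whereas compound 2 with its long chain gives 1540 nM. On that basis the step from compound 2 to compound 4 is expected to be a 10-fold lower number from compound 2 to compound 4 (1.01 log units; beyond the scatter), a move toward stronger inhibition that should lie well beyond the scatter. Compound 4 is therefore expected to give about 150 nM, with a likely range from 30 nM to 800 nM.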

Compound 4, half-maximal inhibitory concentration: 316 nM
Compound 4: the middle estimate sits 2.1-fold (0.32 log units) below what was measured; measured number inside the range.
By their numbers in this assay, from the lowest: compounds 3 and 1 (each within the scatter of the next); then compound 4; then compound 2.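

In this assay, putting the group of 4 heavy atoms in place of the group of 10 heavy atoms, on this aromatic carbon ortho to a methoxy group, gives a 4.9-fold lower number from compound 2 to compound 4 (0.69 log units; beyond the scatter), a move toward stronger inhibition that lies beyond the scatter. For the compounds shown here, this is the first direct reading in the set of a single change, and it shows that the size of the selenium-bearing group at this position matters for the read-out, although the step is modest. The change also removes the oxygen counted in the larger group, so the step reflects the whole swap rather than chain length alone, and nothing available here explains why the number moves.

On these data alone, the two compounds mark only the ends of a range, so it remains open whether a chain of intermediate length, joined through oxygen or directly, would fall between them or whether the change in the number is gradual at all. Also open, as far as these compounds go, is how much depends on the selenium itself, which a plain nitrile, an amine or a carboxylic acid at this position could help to test.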